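A few compounds are considered here, and "the series" means these few. Any claim that something is new, unique, unknown or untested is made for them only; others in the source may bear on it.

Measured so far:
- compound 1, `CC(C)[C@H](C(=O)Nc1nnc(C(F)(F)F)s1)c1ccc(Cl)cc1`, gives 1900 nM in a functional assay on CHO cells for agonist activity at Free fatty acid receptor 2 (Homo sapiens), read by cAMP accumulation; a lower number here means a stronger inhibitor, a higher number a weaker inhibitor
- compound 2, `CC(C)[C@H](C(=O)Nc1ncc[nH]1)c1ccc(Cl)cc1`, gives 20000 nM in this assay
- compound 3, `CC(C)(C)[C@H](C(=O)Nc1ncc(Br)s1)c1ccc(Cl)cc1`, gives 700 nM in this assay

Three compounds share the same core and differ in the ring attached to the amide nitrogen and in the branched group beside the amide. Compound 3 stands at the lowest number of the three. Its nearest neighbour is compound 1, whose number lies beyond the usual scatter above it, and compound 2 sits far higher still. On the numbers seen, compound 3 is therefore the most potent of the three measured compounds.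

Compound 4, `CC(C)(C)[C@H](C(=O)Nc1ncc(C(O)(C(F)(F)F)C(F)(F)F)s1)c1ccc(Cl)cc1`, has not yet been measured. It differs from compound 3 in one place: 2,2,2-trifluoro-1-hydroxy-1-(trifluoromethyl)ethyl in place of bromo on an aromatic carbon. A small single atom is thus exchanged for a much larger group carrying one hydrogen-bond donor and one hydrogen-bond acceptor, on the same five-membered ring.

Among the compounds with values here, no measured pair shows what such an exchange does in this assay, so any expectation rests only on the standing of compound 3. A change of modest size in either direction is expected, and a change no larger than the scatter would not be surprising. Compound 4 is estimated at 400 nM, within a range from 100 nM to 2000 nM, which means an expected step of a 1.8-fold lower number from compound 3 to compound 4 (0.24 log units; within the scatter).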

Compound 4, half-maximal inhibitory concentration: 1200 nM
Compound 4: middle estimate off by 3.0-fold (0.48 log units), on the low side; measured number inside the range.
By their numbers in this assay, from the lowest: compounds 3, 4 and 1 (each within the scatter of the next, the first and the last beyond it); then compound 2.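

In this assay, replacing bromo with 2,2,2-trifluoro-1-hydroxy-1-(trifluoromethyl)ethyl gives a 1.7-fold higher number from compound 3 to compound 4 (0.23 log units; within the scatter), so the two compounds cannot be told apart in this assay. Within the data shown here, this is the first comparison here between compounds that differ in only one place, and it shows that this aromatic carbon, next to the ring sulfur, can carry a group of 10 heavy atoms with a hydrogen-bond donor and acceptor in place of a single bromine atom without a shift beyond the scatter. No supporting measurement bears on what lies behind this result.

On these data alone, because only these two groups are compared at this position, it remains open whether a methyl group, an amine or a carboxylic acid on the same carbon would give a number in the same range. Compounds 1 and 2 differ from compounds 3 and 4 in more than one place, which leaves the separate contributions of the ring on the amide nitrogen and the branched group on the shared core unresolved.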